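The source may hold more compounds than are shown below. What is called first, only, known or untested is meant among the compounds shown, and "the series" means these compounds.

Working notes on the series

The set is built around one shared core carrying a phenyl ring that is either bare or substituted. Compound 1 `O[C@@H]1[C@@H](O)CN[C@H]1c1ccccc1` is the bare phenyl parent in one configuration; compound 2 `O[C@@H]1[C@@H](O)CN[C@H]1c1ccc(F)cc1` carries the fluoro group in the same configuration; compound 3 `O[C@H]1[C@H](O)CN[C@@H]1c1ccc(F)cc1` is the mirror image of compound 2; compound 4 `O[C@H]1[C@H](O)CN[C@@H]1c1ccccc1` is the mirror image of compound 1 and remains to be measured.

In an assay on isolated protein for inhibition of alpha-galactosidase (Coffea arabica), read by spectrophotometry, tested at 1000 uM (a higher number here means more inhibition at the concentration tested (going by the name of the read-out), a lower number less inhibition), compound 2 gives 16.6%, compound 1 gives 2.6%, and compound 3 gives 2%. The step of a number 14 percentage points lower from compound 2 to compound 1 (beyond the scatter) goes with hydrogen in place of fluoro on an aromatic carbon. The step of a number 14.6 percentage points lower from compound 2 to compound 3 (beyond the scatter) goes with the two compounds have the same atoms and bonds and differ only in configuration as drawn: 3 of 3 stereo elements differ (all stereocentres are inverted: mirror images); a stereocentre at a saturated ring carbon is drawn S in compound 2 and R in compound 3; a stereocentre at a saturated ring carbon is drawn S in compound 2 and R in compound 3; a stereocentre at a saturated ring carbon is drawn S in compound 2 and R in compound 3, a step that rests on (the fact that compounds 2 and 3 differ only in the configuration as drawn). Compound 3 and compound 1 sit within the scatter of each other, so no order between them is claimed.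

The change from compound 3 to compound 4 is hydrogen in place of fluoro on an aromatic carbon; the place is the same word for word as in the change from compound 2 to compound 1, so it is the same change, made twice in this set. The earlier occurrence lowered this assay by a modest amount from a moderate starting value. Compound 3, however, starts at 2%, so a drop of the same size cannot be repeated, and the expected step of no change at the digits printed from compound 3 to compound 4 (within the scatter) is close to nil. Compound 4 is therefore estimated at 2%, with a range of -4% to 10% expected.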

Compound 4, a percentage reported as inhibition, at one concentration (the size of the read-out at that concentration, not a potency): 8.6%
Compound 4: the middle estimate sits 6.6 percentage points below what was measured; the measured number falls inside the stated range.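

Carrying hydrogen in place of fluoro over to the mirror-image core does not reproduce the earlier step: in this assay it now gives a number 6.6 percentage points higher from compound 3 to compound 4 (within the scatter) and, set beside the first occurrence, the two do not agree: the same change on two cores in this assay, a number 14 percentage points lower (beyond the scatter) from compound 2 to compound 1 and a number 6.6 percentage points higher (within the scatter) from compound 3 to compound 4, 20.6 percentage points apart, beyond the scatter of two such steps. The parent pair gives a number 6 percentage points higher from compound 1 to compound 4 (within the scatter), so inverting all stereocentres leaves no step beyond the scatter for the bare phenyl compounds, unlike the fluoro pair: the fact that compounds 1 and 4 differ only in the configuration as drawn. For the compounds shown here, this shows that, in these two pairs, the step seen for this change on one core cannot be assumed on its mirror image, but it does not establish a rule for the series or give the second step a direction, since that step lies within the scatter and only one change on two cores is compared.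

The compounds shown carry only fluoro or hydrogen at this place on the phenyl ring, so how a chloro, methoxy or amine group there would read on either core stays open. As far as these compounds go, all readings are percentages at a single concentration, so the potency of each compound and the behaviour of the change across a range of concentrations also remain open.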